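The source may hold more compounds than are shown below. What is called first, only, known or untested is meant among the compounds shown, and "the series" means these compounds.

In a functional assay on HeLa cells (Homo sapiens) for antiproliferative activity, read by MTT assay, with a stated time of 72 h (on this read-out higher numbers stand for weaker inhibition and lower numbers for stronger inhibition), compound 3, `CCCCCC#Cc1cn(CCC(COC(C)=O)COC(C)=O)c(=O)n(C(=O)c2ccccc2)c1=O`, gives 53700 nM. Compound 1, `CC(=O)OCC(CCn1cc(C#Cc2cc(F)cc(F)c2)c(=O)n(C(=O)c2ccccc2)c1=O)COC(C)=O`, gives 64500 nM in this assay, and the step of a 1.2-fold lower number from compound 1 to compound 3 (0.08 log units; within the scatter) places compound 3 alongside compound 1 rather than apart from it. Compound 2, `CC(=O)OCC(CCn1cc(C#CC2CC2)c(=O)n(C(=O)c2ccccc2)c1=O)COC(C)=O`, reaches only the limit > 100000 nM in this assay, a limit and not a number. The step of an at least 1.5-fold higher number from compound 1 to compound 2 (0.19 log units; that floor lies within the scatter) and the step of an at least 1.8-fold lower number from compound 2 to compound 3 (0.27 log units; that floor lies within the scatter) thus leave all three compounds undistinguished on these numbers (the limit of > 100000 nM in this assay, at which 1 of the 3 values shown sits). Compound 4, `CCCCCCCCC#Cc1cn(CCC(COC(C)=O)COC(C)=O)c(=O)n(C(=O)c2ccccc2)c1=O`, differs from compound 3 by propyl in place of hydrogen on a saturated chain carbon, five bonds along the chain from a triple-bonded carbon. Within the data shown here, the steps that bear on it are those that exchanged the group on the triple-bonded carbon, a 1.2-fold lower number from compound 1 to compound 3 (0.08 log units; within the scatter) and an at least 1.8-fold lower number from compound 2 to compound 3 (0.27 log units; that floor lies within the scatter), each small or only a limit; the change to compound 4 merely lengthens that chain. Compound 4 is therefore expected to show a step of a 1.0-fold higher number from compound 3 to compound 4 (0.01 log units; within the scatter) in this assay, none beyond the scatter. Compound 4 is estimated at 55000 nM, within 22000 nM to 150000 nM.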

Compound 4, half-maximal inhibitory concentration: 32400 nM
Beside the measured number, compound 4's estimate is 1.7-fold (0.23 log units) above it, within the range that was stated.
By their numbers in this assay, from the lowest: compounds 4, 3 and 1 (each within the scatter of the next). At a limit, above all of these: compound 2.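

In this assay, propyl in place of hydrogen on a saturated chain carbon, five bonds along the chain from a triple-bonded carbon, gives a 1.7-fold lower number from compound 3 to compound 4 (0.22 log units; within the scatter), and exchanging 3,5-difluorophenyl for octyl gives a 2.0-fold lower number from compound 1 to compound 4 (0.30 log units; within the scatter), so neither change separates the compounds it joins. Among these compounds, what is new is the first step beyond the scatter at this position: octyl in place of cyclopropyl gives an at least 3.0-fold lower number from compound 2 to compound 4 (0.48 log units; beyond the scatter), a floor and not an exact size. Compound 2 is the one compound that stands at a limit, which is not a number: the limit of > 100000 nM in this assay, at which 1 of the 4 values shown sits.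

The compounds shown leave open whether a longer chain than octyl, an amine or a carboxylic acid on the triple-bonded carbon would stand apart from compound 4 in this assay. They also leave open where compound 2 would fall as a number.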